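Adding a Pyridinyl Ring to the Bare Oxazole Core

A few compounds are considered here, and "the series" means these few. Any claim that something is new, unique, unknown or untested is made for them only; others in the source may bear on it.

Compound 1 `CCCCCCCC/C=C\CCCCCCC(=O)c1ncc(-c2ccoc2)o1`: 610 nM
Compound 2 `CCCCCCCC/C=C\CCCCCCC(=O)c1ncc(-c2ccco2)o1`: 54 nM
Compound 3 `CCCCCCCC/C=C\CCCCCCC(=O)c1ncco1`: 17 nM

All three were tested in an assay on isolated protein for inhibition of Fatty-acid amide hydrolase 1 (Homo sapiens); a higher number here means a weaker inhibitor, a lower number a stronger inhibitor. Compound 3 gives the lowest number of the three: the steps of a 3.2-fold lower number from compound 2 to compound 3 (0.50 log units; beyond the scatter) and a 36-fold lower number from compound 1 to compound 3 (1.55 log units; beyond the scatter) both lie beyond the scatter, and an 11-fold lower number from compound 1 to compound 2 (1.05 log units; beyond the scatter) separates the two furanyl compounds from each other. Compound 4 `CCCCCCCC/C=C\CCCCCCC(=O)c1ncc(-c2ccncc2)o1` has not yet been measured in this assay. It differs from compound 3 by pyridin-4-yl in place of hydrogen on an aromatic carbon. Both measured additions of a furanyl group at this position raised the number, one modestly and one strongly, so adding a pyridin-4-yl group is expected to raise it as well, by an amount estimated as a 5.9-fold higher number from compound 3 to compound 4 (0.77 log units; beyond the scatter). Compound 4 is therefore expected to give about 100 nM, with a range from 25 nM to 700 nM.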

Compound 4, inhibition constant: 56 nM
For compound 4 the middle estimate is 1.8-fold (0.25 log units) above the measured one; measured number inside the range.
By their numbers in this assay, from the lowest: compound 3; then compounds 2 and 4 (each within the scatter of the next); then compound 1.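

The pyridin-4-yl group still gives a weaker inhibitor than bare hydrogen (a 3.3-fold higher number from compound 3 to compound 4 (0.52 log units; beyond the scatter)), but replacing furan-2-yl with it leaves the number level (a 1.0-fold higher number from compound 2 to compound 4 (0.02 log units; within the scatter)). A six-membered aromatic ring at this position can therefore match the better five-membered one. The gap to the furan-3-yl compound remains large (an 11-fold lower number from compound 1 to compound 4 (1.04 log units; beyond the scatter)), so among these compounds, ring size alone does not set the number.

Going by these compounds, whether a phenyl ring, pyridin-3-yl or an amine here would behave like pyridin-4-yl remains open. Nothing measured here explains these differences.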